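The compounds below may be only part of what the source reports. "The series", "measured", "known", "first", "only" and "open" are said of these compounds alone.

Measured compounds:
compound 1, `COc1cc(/C=C/C(=O)c2cccc(-n3cc(-c4ccc(Cl)cc4)[nH]c3=O)c2)cc(OC)c1OC`, 6460 nM
compound 2, `COc1cc(/C=C/C(=O)c2cccc(-n3cc(-c4ccccc4)[nH]c3=O)c2)cc(OC)c1OC`, 3020 nM
compound 3, `COc1ccc(-c2cn(-c3cccc(C(=O)/C=C/c4ccc(O)c(OC)c4)c3)c(=O)[nH]2)cc1`, 6080 nM

In a functional assay on TK-10 cells (Homo sapiens) for inhibition (on this read-out higher numbers stand for weaker inhibition of growth and lower numbers for stronger inhibition of growth), compound 3 sits within the scatter of both compound 1 and compound 2, so the three numbers cannot be ordered with confidence. Going by the values given here, the one step that is resolved, a 2.1-fold lower number from compound 1 to compound 2 (0.33 log units; beyond the scatter), concerns the aryl group on the core and does not touch the chain end that changes here.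

Compound 4, `COc1ccc(-c2cn(-c3cccc(C(=O)/C=C/c4cc(OC)c(OC)c(OC)c4)c3)c(=O)[nH]2)cc1`, differs from compound 3 by 3,4,5-trimethoxyphenyl in place of 4-hydroxy-3-methoxyphenyl on a double-bonded chain carbon bound to a double-bonded chain carbon. Compounds 1 and 2 already carry the 3,4,5-trimethoxyphenyl on the chain, and compound 3 with the 4-hydroxy-3-methoxyphenyl gives a number within their scatter, so the trimethoxy group at this place is not tied to any step beyond the scatter. Among the compounds with values here, no measured pair isolates exactly this change.

Compound 4 is therefore expected to show a 1.2-fold lower number from compound 3 to compound 4 (0.08 log units; within the scatter), a step not beyond the scatter. The estimate for compound 4 in this assay is 5000 nM, with a range from 2000 nM to 12000 nM.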

Compound 4, concentration for 50% growth inhibition: 3040 nM
For compound 4 the middle estimate is 1.6-fold (0.22 log units) above the measured one; measured number inside the range.
By their numbers in this assay, from the lowest: compounds 2, 4, 3 and 1 (each within the scatter of the next, the first and the last beyond it).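

In this assay, the change at the chain end gives a 2.0-fold lower number from compound 3 to compound 4 (0.30 log units; within the scatter), so replacing 4-hydroxy-3-methoxyphenyl with 3,4,5-trimethoxyphenyl, which also removes the hydrogen-bond donor, produces no resolved shift with the methoxy aryl group on the core. On the aromatic carbon of that aryl group, methoxy in place of hydrogen gives a 1.0-fold higher number from compound 2 to compound 4 (0.00 log units; within the scatter), so these two substituents cannot be told apart. Methoxy in place of chloro gives a 2.1-fold lower number from compound 1 to compound 4 (0.33 log units; beyond the scatter), a modest step, leaving chloro as the only one of the three substituents resolved from the others.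

Still open, on these data alone, is whether an amine or a carboxylic acid on that aromatic carbon would separate from hydrogen and methoxy as chloro does. No independent data bear on the reason for these numbers.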